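A Cytotoxicity Limit Carried Toward Compound 4

The source may hold more compounds than are shown below. What is called first, only, known or untested is meant among the compounds shown, and "the series" means these compounds.

Three compounds built on a shared core were examined in an ADME assay on HEK293 cells (Homo sapiens) for cytotoxicity, read by CellTiter-Glo and resazurin assay, with a stated time of 72 h; on this read-out higher numbers stand for an effect only at larger amounts of compound and lower numbers for an effect already at smaller amounts. Compound 1 `CC(C)N(Cc1cccc(OCCCCCC(=O)O)c1)C(=O)c1ccc(-c2cccc(N(C)C)c2)cc1` reached only the limit of the assay: in this assay compound 1 gives > 26000 nM. Compound 2 `CCOC(=O)CCCCCOc1cccc(CN(C(=O)c2ccc(-c3ccc4ccccc4c3)cc2)C(C)C)c1` also stops at a limit rather than a number, and in this assay compound 2 gives > 26000 nM. Compound 3 `CCOC(=O)CCCCCOc1cccc(CN(C(=O)c2ccc(-c3cc4ccccc4n3S(=O)(=O)c3ccccc3)cc2)C(C)C)c1` behaves the same way, giving > 26000 nM in this assay as a limit. Compound 2 therefore stands exactly where its two companions stand, and on these numbers nothing separates it from compound 1 or compound 3.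

Compound 4 `CCOC(=O)CCCCCOc1cccc(CN(C(=O)c2ccc(-c3cc(F)cc(OC)c3)cc2)C(C)C)c1` has not yet been measured in this assay. It differs from compound 2 by 3-fluoro-5-methoxyphenyl in place of naphthalen-2-yl on an aromatic carbon. Among the measured compounds shown here, no step between two measured compounds is available in this assay, so the size of a change cannot be read from any measured pair. Because the limit of > 26000 nM in this assay, at which 3 of the 3 values shown sit, holds every value shown, the step to compound 4 is expected to be none beyond the scatter, most likely ending again at a limit.

Compound 4 is expected to give about 40000 nM in this assay, within a range from 20000 nM to 100000 nM. The step this estimate implies, a step that the limit leaves unreadable from compound 2 to compound 4, is expected to lie within the scatter.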

Compound 4, half-maximal effective concentration: > 26000 nM
Compound 4 ended at the assay's limit (the forecaster's own chance of this, stated with the estimate: 85%); the middle value is on the limit's open side.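

Among the compounds shown here, compound 4 stops at a limit just as compound 2 does, so no step from compound 2 to compound 4 can be read in this assay, the two limits giving no size for it: the limit of > 26000 nM in this assay, at which 4 of the 4 values shown sit.

The compounds shown leave open where any of them would give an actual number in this assay, and so whether 3-fluoro-5-methoxyphenyl and naphthalen-2-yl differ at all on this read-out.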